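The compounds below may be only part of what the source reports. "The series", "measured", "known", "first", "only" and "open" are said of these compounds alone.

Compound 1 `Cc1cccc(/C=C2\CCC/C(=C\c3ccccc3)C2=O)c1` is one of three compounds assessed in an assay on isolated protein for inhibition of Alpha glucosidase (Homo sapiens), with stated times of 5 min and 15 min, tested at 50 uM (on this read-out lower numbers stand for less inhibition and higher numbers for more inhibition at the one concentration tested (going by the name of the read-out)), where compound 1 gives 47.9%. Alongside it stand compound 2 `O=C(/C=C(O)/C=C/c1ccc(O)cc1)c1cc(Cl)ccc1O`, which in this assay gives 45.3%, and compound 3 `O=C(C1=C(O)/C(=C/c2cccc(O)c2)CCC1)c1ccccc1`, which gives 43.2%. On these numbers compound 1 carries the largest figure of the three, yet neither compound 2 nor compound 3 is separated from it by more than the usual scatter, so the three cannot be told apart on this read-out. Among the measured compounds shown here, no pair among them differs in a single place, so no measured step is available to guide what one change does.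

Compound 4 `O=C1/C(=C/c2ccccc2)CCC/C1=C\c1ccc(Br)cc1` has not yet been measured. It differs from compound 1 in one place: 4-bromophenyl in place of 3-methylphenyl on a double-bonded chain carbon bound to a double-bonded ring carbon. The three measured compounds, all within the scatter of one another, give no reason to expect this change to move the number out of the scatter in either direction. Compound 4 is therefore expected to give about 45% in this assay, with a likely range from 30% to 60%. That estimate corresponds to an expected step of a number 2.9 percentage points lower from compound 1 to compound 4 (within the scatter), which is expected to remain within the scatter.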

Compound 4, a percentage reported as inhibition, at one concentration (the size of the read-out at that concentration, not a potency): 29.1%
For compound 4 the middle estimate is 15.9 percentage points above the measured one; the measured number lies below the stated range.
By their numbers in this assay, from the lowest: compound 4; then compounds 3, 2 and 1 (each within the scatter of the next).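

In this assay, among the compounds shown here, 4-bromophenyl in place of 3-methylphenyl on a double-bonded chain carbon bound to a double-bonded ring carbon gives a number 18.8 percentage points lower from compound 1 to compound 4 (beyond the scatter), the first single change in this set that can be read, and it shows that this position is not indifferent to the group it carries. The step appears even though the two groups match in everything counted for them: the same number of heavy atoms, one six-membered aromatic ring of carbon only, no hydrogen-bond donors or acceptors and no net charge, so those counts alone do not tell these two groups apart on this read-out. No measurement shown here accounts for the step.

Two things change together in this step, the substituent and where it stands on the phenyl ring, and the compounds shown leave open whether the bromine or its placement matters, a question that 3-bromophenyl or 4-methylphenyl would separate. They also leave open how this position would respond to a different kind of group, such as an amine or a carboxylic acid on that phenyl ring.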